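Swapping Fluoro for Chloro on the Amide-Bound Ring

The compounds below may be only part of what the source reports. "The series", "measured", "known", "first", "only" and "open" are said of these compounds alone.

Of the compounds shown here, three built on one shared core have been measured in a functional assay on CHO cells for antagonist activity at Orexin/Hypocretin receptor type 1 (Homo sapiens), read by FLIPR and calcium flux; a lower number here means a stronger inhibitor, a higher number a weaker inhibitor. Compound 1 `COc1ccc(C)cc1NC(=O)CSc1nnc(-c2ccoc2C)n1Cc1ccco1` gives 2510 nM. Compound 2 `Cc1occc1-c1nnc(SCC(=O)Nc2ccc(F)c(Cl)c2)n1Cc1ccco1` gives 1000 nM, which amounts to a 2.5-fold lower number from compound 1 to compound 2 (0.40 log units; beyond the scatter). Compound 3 `Cc1occc1-c1nnc(SCC(=O)Nc2ccc(F)cc2)n1Cc1ccco1` reaches only the limit of the assay, > 15800 nM, so no number is known for it. For the measured compounds named here, measured against compound 1 this is an at least 6.2-fold higher number from compound 1 to compound 3 (0.79 log units; beyond the scatter), and measured against compound 2 it is an at least 15-fold higher number from compound 2 to compound 3 (1.19 log units; beyond the scatter), where the only change was hydrogen in place of chloro on an aromatic carbon.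

Compound 4 `Cc1occc1-c1nnc(SCC(=O)Nc2ccc(Cl)cc2)n1Cc1ccco1` differs from compound 3 in one place: chloro in place of fluoro on an aromatic carbon. The step from compound 2 to compound 3 bears most directly on this, since losing a chloro there cost a large amount; putting a chloro back, in exchange for a fluoro, is therefore expected to move the number downward, toward stronger inhibition. Because compound 3 sits at a limit, the size of the expected step of an at least 2.6-fold lower number from compound 3 to compound 4 (0.42 log units; beyond the scatter) is uncertain. Compound 4 is estimated at 6000 nM, within a range from 1500 nM to 25000 nM.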

Compound 4, inhibition constant: 2000 nM
For compound 4 the middle estimate is 3.0-fold (0.48 log units) above the measured one, within the range that was stated.
By their numbers in this assay, from the lowest: compounds 2, 4 and 1 (each within the scatter of the next, the first and the last beyond it). At a limit, above all of these: compound 3.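

At this one place on the ring, para to a large group, the atom matters: with chloro in place of fluoro in this assay, the piece records an at least 7.9-fold lower number from compound 3 to compound 4 (0.89 log units; beyond the scatter). Compound 3 has only a limit, so this step gives a minimum and not a true size: the limit of > 15800 nM in this assay, at which 1 of the 4 values shown sits. The earlier compounds shown here showed the loss of a chloro from the 3-chloro-4-fluorophenyl ring, whereas a lone chloro on the 4-chlorophenyl ring now leaves no difference that can be told apart, with a 2.0-fold higher number from compound 2 to compound 4 (0.30 log units; within the scatter) and a 1.3-fold lower number from compound 1 to compound 4 (0.10 log units; within the scatter).

As far as these compounds go, whether bromo, methyl or trifluoromethyl at this same place would match chloro remains open. Also open, from the compounds shown here alone, is the true number for compound 3, which would fix the size of the change from fluoro to chloro.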